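A Difluoromethoxy Group Replaces a Limit-Bound Substituent

The source may report more compounds than this note shows. Statements on the series, on what has been measured and on what is new or still open speak of the compounds shown alone.

In a functional assay on MCF cells (Homo sapiens) for antiproliferative activity, with a stated time of 72 h (a higher number here means a weaker inhibitor, a lower number a stronger inhibitor), compound 3 `Cc1ccc(O)c(CNc2ncnc3c2ncn3[C@@H]2O[C@H](CO)[C@@H](O)[C@H]2O)c1` gives no number, only a limit of > 166000 nM. Compound 1 `COc1ccc(CNc2ncnc3c2ncn3[C@@H]2O[C@H](CO)[C@@H](O)[C@H]2O)c(OC)c1` likewise gives only a limit, > 166000 nM. Compound 2 `Cc1cccc(CNc2ncnc3c2ncn3[C@@H]2O[C@H](CO)[C@@H](O)[C@H]2O)c1O`, by contrast, gives a measured 6900 nM.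

Compound 4 `OC[C@H]1O[C@@H](n2cnc3c(NCc4ccccc4OC(F)F)ncnc32)[C@H](O)[C@@H]1O` differs from compound 3 in a single place, a saturated chain carbon bound to a nitrogen on an aromatic ring, where 2-(difluoromethoxy)phenyl stands in place of 2-hydroxy-5-methylphenyl: 2-(difluoromethoxy)phenyl in place of 2-hydroxy-5-methylphenyl on a saturated chain carbon bound to a nitrogen on an aromatic ring.

Earlier changes at this place bear directly on the new one. Two were large and beyond the scatter: an at least 24-fold lower number from compound 1 to compound 2 (1.38 log units; beyond the scatter) and an at least 24-fold higher number from compound 2 to compound 3 (1.38 log units; beyond the scatter). The third, a step that the two limits leave unreadable from compound 1 to compound 3, gives no size. These steps show that this place can move the reading strongly, but not which way a new group will move it. Compound 1 has no hydroxy group and compound 3 has one, yet both sit at the limit of > 166000 nM in this assay, at which 2 of the 3 values shown sit, so a reading near the limit remains likely for compound 4.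

The expected step is an at least 2.3-fold lower number from compound 3 to compound 4 (0.37 log units; beyond the scatter), towards a lower number if a number can be read at all. Compound 4 is estimated at 70000 nM, with an expected range from 8000 nM to 200000 nM.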

Compound 4, half-maximal inhibitory concentration: > 166000 nM
Compound 4: only a limit was reported; the forecaster's own chance of this, stated with the estimate: 55%; at least 2.3-fold (0.37 log units) between middle value and limit.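

In this assay, going by these compounds alone, compound 4 is a third compound without a readable number: its entry is a limit, and 2-(difluoromethoxy)phenyl, with 0 hydrogen-bond donors, ends at the same limit as the 2-hydroxy-5-methylphenyl of compound 3, with 1 hydrogen-bond donor: the limit of > 166000 nM in this assay, at which 3 of the 4 values shown sit. The only step involving compound 4 that can be read is an at least 24-fold higher number from compound 2 to compound 4 (1.38 log units; beyond the scatter), so 2-hydroxy-3-methylphenyl remains the only group at this place, on a saturated chain carbon bound to a nitrogen on an aromatic ring, that gives a measured value. The steps from compound 1 and from compound 3 to compound 4 join one limit to another and cannot be read, so the new group cannot be ranked against either of those two groups.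

The compounds shown leave open which features of 2-hydroxy-3-methylphenyl are needed for a measured value, given that compound 3 carries the same hydroxy and methyl groups on its phenyl ring and gives only a limit. They also leave open whether an amine in place of the hydroxy group of 2-hydroxy-3-methylphenyl, or a difluoromethoxy group in its place with the methyl group kept, would give a measured value in this assay.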